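The source may hold more compounds than are shown below. What is called first, only, known or untested is meant among the compounds shown, and "the series" means these compounds.

Measured in an ADME assay on Vero cells (Chlorocebus sabaeus) for cytotoxicity, with a stated time of 72 h; a lower number here means a stronger inhibitor, a higher number a weaker inhibitor:
- compound 1 `CCOC(=O)c1cc(/C=C/c2cccc(OC)c2)on1`: > 128000 nM
- compound 2 `CCOC(=O)c1cc(/C=C/c2c(Cl)cncc2Cl)on1`: > 128000 nM
- compound 3 `CCC(CC)OC(=O)c1cc(/C=C/c2c(Cl)cncc2Cl)on1`: > 128000 nM

All three entries are limits, not numbers. In this assay compound 3 stands at > 128000 nM, which is a limit, and the series as a whole shows (the limit of > 128000 nM in this assay, at which 3 of the 3 values shown sit).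

Compound 4 `CCCCCCCCOC(=O)c1cc(/C=C/c2c(Cl)cncc2Cl)on1` carries octyl in place of pentan-3-yl on an oxygen next to a carbonyl group.

One measured step changes this same group, a step that the two limits leave unreadable from compound 2 to compound 3, and it gives no size to carry over. With compound 3 at > 128000 nM, no readable step is expected, and a result at the same limit is the likeliest outcome. The expected change is a number no higher from compound 3 to compound 4 (the limit leaves the size open). For compound 4 the estimate is 128000 nM, with an expected range of 50000 nM to 128000 nM.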

Compound 4, half-maximal inhibitory concentration: > 128000 nM
Compound 4: only a limit was reported; the forecaster's own chance of this, stated with the estimate: 75%; the middle value lies on the limit itself.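

In this assay, going by these compounds alone, compound 4 gives > 128000 nM as a limit, so no step from compound 2 or compound 3 to compound 4 can be read. The compounds shown leave open which change on that oxygen, if any, would bring a value off the limit: the limit of > 128000 nM in this assay, at which 4 of the 4 values shown sit.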